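The source may hold more compounds than are shown below. What is called first, only, known or untested is meant among the compounds shown, and "the series" means these compounds.

Measured compounds:
Compound 1, `CC1=NC(C)=C(C(=O)O)C(c2ccccc2[N+](=O)[O-])/C1=C(\O)OC/C=C/c1ccccc1`. In a functional assay on thoracic aorta for inhibition of Voltage-gated L-type calcium channel (Rattus norvegicus) (a lower number here means a stronger inhibitor, a higher number a weaker inhibitor), compound 1 gives 31 nM.
Compound 2, `CC1=NC(C)=C(C(=O)O)C(c2cccc(C(=O)O)c2)/C1=C(\O)OC/C=C/c1ccccc1`. In this assay compound 2 reaches only the limit of the assay, > 10000 nM.

Among the compounds with values here, compound 2 therefore stands at the weak end of the pair: its value is a limit, not a number, and this is the one value of the two that sits at the limit of > 10000 nM in this assay, at which 1 of the 2 values shown sits. Within the data shown here, the single measured step, 3-carboxyphenyl in place of 2-nitrophenyl on a saturated ring carbon, gave an at least 320-fold higher number from compound 1 to compound 2 (2.50 log units; beyond the scatter).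

Compound 3, `CC1=NC(C)=C(C(=O)O)C(c2cccc(I)c2)/C1=C(\O)OC/C=C/c1ccccc1`, has not yet been measured in this assay. It differs from compound 2 by iodo in place of carboxy on an aromatic carbon. Among the measured compounds shown here, the only measured step that bears on this change is the one from compound 1 to compound 2, in which the arrival of the carboxy group on the phenyl ring coincided with the loss of measurable inhibition. Removing that carboxy group in favour of iodo is expected to reverse most of that loss, so a large step toward a lower number is expected, though the exact size is uncertain since compound 2 is known only as a limit. Compound 3 is expected to give about 80 nM in this assay, with a range from 15 nM to 800 nM. This estimate corresponds to an expected step of an at least 120-fold lower number from compound 2 to compound 3 (2.09 log units; beyond the scatter).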

Compound 3, half-maximal inhibitory concentration: 13 nM
Compound 3: middle estimate off by 6.2-fold (0.79 log units), on the high side; measured number below the stated range.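

In this assay, compound 2 remains a limit rather than a number, so the size of the step from it is a bound: the limit of > 10000 nM in this assay, at which 1 of the 3 values shown sits. Exchanging 3-carboxyphenyl for 3-iodophenyl gave an at least 760-fold lower number from compound 2 to compound 3 (2.88 log units; beyond the scatter), which shows that the loss in compound 2 does not belong to this aromatic carbon as such, since a group placed there, meta to a large group, can go with strong inhibition; among the compounds shown, the loss goes with the carboxy group. Within the data shown here, the comparison with the first compound of the series adds a modest gain, a 2.4-fold lower number from compound 1 to compound 3 (0.38 log units; beyond the scatter), so 2-nitrophenyl on the saturated ring carbon is not needed for inhibition at this level, and 3-iodophenyl can take its place without loss.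

With only carboxy and iodo compared on this aromatic carbon, the compounds shown cannot say whether the strong inhibition needs the iodo itself or only the absence of carboxy; a bromo group, a methyl group, an amine or a plain unsubstituted phenyl there would separate the two readings. Going by these compounds, whether 3-iodophenyl keeps its advantage over 2-nitrophenyl with a longer chain or an amide in place of the cinnamyl ester side of the core also stays open.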